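The compounds below may be only part of what the source reports. "The series", "measured", "known", "first", "only" and "open" are said of these compounds alone.

Measured in a functional assay on NCI-H460 cells (Homo sapiens) for cytotoxicity, read by MTT assay, with a stated time of 72 h; a higher number here means a weaker inhibitor, a lower number a stronger inhibitor:
Compound 1 `COc1cc2c(Oc3ccc(NC(=O)c4nn(-c5ccccc5F)c(=O)c5ccccc45)cc3F)ccnc2cc1OCCCN1CCCC1`: 230 nM
Compound 2 `COc1cc2c(Oc3ccc(NC(=O)c4nn(-c5ccccc5Br)c(=O)c5ccccc45)cc3F)ccnc2cc1OCCCN1CCCC1`: 320 nM

Going by the values given here, compound 1 stands at the low end of these two numbers, yet the only measured step, a 1.4-fold higher number from compound 1 to compound 2 (0.14 log units; within the scatter), a bromo in place of fluoro on an aromatic carbon, lies within the scatter, so the two compounds cannot be told apart. Compound 3 `COc1cc2c(Oc3ccc(NC(=O)c4nn(-c5ccccc5F)c(=O)c5ccccc45)cc3F)ccnc2cc1OCCCN1CCCCC1` differs from compound 1 at another place: piperidin-1-yl in place of pyrrolidin-1-yl on a saturated chain carbon, three bonds along the chain from an oxygen on an aromatic ring. Among the compounds with values here, no measured step touches this part of the molecule, so nothing points to a shift in either direction. The number for compound 3 is expected to stay close to that of compound 1, an estimated 1.1-fold higher number from compound 1 to compound 3 (0.04 log units; within the scatter), giving 250 nM with a range of 110 nM to 560 nM.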

Compound 3, half-maximal inhibitory concentration: 160 nM
For compound 3 the middle estimate is 1.6-fold (0.19 log units) above the measured one; measured number inside the range.
By their numbers in this assay, from the lowest: compounds 3, 1 and 2 (each within the scatter of the next).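

In this assay the move from pyrrolidin-1-yl to piperidin-1-yl gives a 1.4-fold lower number from compound 1 to compound 3 (0.16 log units; within the scatter) and so leaves the two compounds indistinguishable. Going by these compounds alone, this is the first reading at the end of the 3-(pyrrolidin-1-yl)propyl chain, and it shows that a six-membered non-aromatic ring can replace the five-membered one here with no change beyond the scatter. Nothing available bears on how this swap acts on the cells. On these data alone, whether morpholin-4-yl, or an open-chain dimethylamino group, would fit equally well remains open. So does the effect of a longer or shorter chain.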